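Fluorophenyl to Dimethoxyphenyl on the Shared Core

The compounds below may be only part of what the source reports. "The series", "measured", "known", "first", "only" and "open" are said of these compounds alone.

Measured so far:
compound 1 `COc1cc(C2=NN(C(C)=O)C(c3cccc(F)c3)O2)cc(OC)c1OC`: 43.5%
compound 2 `COc1cc(C2=NN(C(C)=O)C(c3ccc(F)c(F)c3)O2)cc(OC)c1OC`: 46.9%
compound 3 `COc1cc(C2=NN(C(C)=O)C(c3ccccc3F)O2)cc(OC)c1OC`: 31.6%

In a functional assay on PC-3 cells (Homo sapiens) for antiproliferative activity, read by MTT assay, tested at 5 uM (a lower number here means a weaker effect, a higher number a stronger effect of the compound at the concentration tested), compound 3 stands lowest of the three numbers. The step of a number 3.4 percentage points higher from compound 1 to compound 2 (within the scatter) lies within the scatter, whereas both steps arriving at compound 3, a number 11.9 percentage points lower from compound 1 to compound 3 (beyond the scatter) and a number 15.3 percentage points lower from compound 2 to compound 3 (beyond the scatter), are modest drops beyond it. Compound 4 `COc1cc(C2=NN(C(C)=O)C(c3cccc(OC)c3OC)O2)cc(OC)c1OC` differs from compound 3 by 2,3-dimethoxyphenyl in place of 2-fluorophenyl on a saturated ring carbon. For the measured compounds named here, no measured step exchanges a fluorophenyl for a methoxy-bearing group, so nothing bears directly on this change; the only hint is that every measured step into the 2-fluorophenyl compound 3 was a loss, so leaving that group may recover part of it. For compound 4 a small rise is expected, a number 6.4 percentage points higher from compound 3 to compound 4 (within the scatter), giving an estimated 38% within 20% to 56%.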

Compound 4, a percentage reported as inhibition, at one concentration (the size of the read-out at that concentration, not a potency): 58.2%
Compound 4: the middle estimate sits 20.2 percentage points below what was measured; measured number outside the range, above it.
By their numbers in this assay, from the lowest: compound 3; then compounds 1 and 2 (each within the scatter of the next); then compound 4.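

In this assay, the change to 2,3-dimethoxyphenyl gives a number 26.6 percentage points higher from compound 3 to compound 4 (beyond the scatter), a number 14.7 percentage points higher from compound 1 to compound 4 (beyond the scatter) and a number 11.3 percentage points higher from compound 2 to compound 4 (beyond the scatter). This position therefore accepts a larger group carrying two methoxy groups, and compound 4 is the strongest of the four at the concentration tested, above all three fluorophenyl compounds. Nothing available explains this rise. The compounds shown leave open whether a single methoxy group would give the same gain, and whether both methoxy groups are needed. They also leave open how a hydroxy group or an amine on this phenyl ring would compare.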